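This account rests on a few compounds, and the source may have more. Where it says the series, first, only, none or still open, it means among the compounds named here.

Three compounds share one core, a ring built from two amide groups, carrying two arylidene arms. Compound 1 `COc1ccccc1/C=c1\c(=O)[nH]/c(=C/c2cccc(Cl)c2Cl)c(=O)n1C` and compound 3 `COc1ccccc1/C=c1/[nH]c(=O)/c(=C\c2nc[nH]c2C(C)(C)C)[nH]c1=O` are the measured anchors. In a functional assay on BGC-823 cells (Homo sapiens) for cytotoxicity, read by CCK-8 assay, with a stated time of 72 h (a lower number here means a stronger inhibitor, a higher number a weaker inhibitor), compound 1 gives 300 nM, and in this assay compound 3 gives 90 nM. Compound 2 `C=CCn1c(=O)/c(=C\c2ccc(F)c(Br)c2)[nH]c(=O)/c1=C\c1ccccc1OC` carries an allyl group on one ring nitrogen and a 3-bromo-4-fluorophenyl arm; in this assay compound 2 is reported as "not active" (no number reported), so no single number stands for it, and it cannot be placed on the same scale as compound 1 or compound 3. All that can be said is that compound 2 falls short of both.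

Compound 4 `C=CCn1c(=O)/c(=C\c2ccc(Cl)c(Cl)c2)[nH]c(=O)/c1=C\c1ccccc1OC` is not yet measured. Against compound 2 the change is 3,4-dichlorophenyl in place of 3-bromo-4-fluorophenyl on a double-bonded chain carbon bound to an aromatic carbon. The two halogenated arms are the same size and the same in donors and acceptors; only the halogens differ. Within the data shown here, no measured pair shows what such a swap does, so no step can be quoted, and the expectation rests on compound 2 alone: no movement beyond the scatter, most likely again weak or reported only as a limit. In this assay compound 4 is therefore expected to come in near 20000 nM, within a range from 3000 nM to 100000 nM.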

Compound 4, half-maximal inhibitory concentration: "not active" (no number reported)
The entry for compound 4 holds no number; there is nothing to compare the estimate with.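

Compound 2 and compound 4 are both reported as not active in this assay, with no number for either, so no step can be read between them. No other evidence bears on this result. The compounds shown leave open what a change of halogens on this arm does in a compound that gives a number.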